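Trading the chain hydroxyl for a longer phenoxy chain

The compounds below may be only part of what the source reports. "The series", "measured", "known", "first", "only" and "open" are said of these compounds alone.

Compound 1 `O=C(O)c1csc([C@H]2CC[C@@H]3[C@@H](/C=C/[C@@H](O)COc4ccccc4)[C@H](O)C[C@@H]3O2)n1` gives 7.9 nM in a functional assay on CHO cells for agonist activity at prostaglandin E2 receptor EP2 subtype (Homo sapiens), read by HTRF and cAMP accumulation, with a stated time of 30 min (on this read-out lower numbers stand for an effect already at smaller amounts and higher numbers for an effect only at larger amounts of compound), the highest of the three numbers shown. Compound 2 `O=C(O)c1csc([C@H]2CC[C@@H]3[C@@H](COc4cccc(F)c4)[C@H](O)C[C@@H]3O2)n1` gives 5.4 nM, which lies within the scatter of compound 1, while compound 3 `O=C(O)c1csc([C@H]2CC[C@@H]3[C@@H](COc4cccc(OC(F)(F)F)c4)[C@H](O)C[C@@H]3O2)n1` gives 0.9 nM, a gap beyond the scatter. Among the measured compounds shown here, the only measured step, a 6.0-fold lower number from compound 2 to compound 3 (0.78 log units; beyond the scatter), concerns a substituent on an aromatic carbon and so does not bear on the change studied here. Compound 4 `O=C(O)c1csc([C@H]2CC[C@@H]3[C@@H](/C=C/CCCOc4ccccc4)[C@H](O)C[C@@H]3O2)n1` differs from compound 1 by 3-phenoxypropyl in place of 1-hydroxy-2-phenoxyethyl on a double-bonded chain carbon bound to a double-bonded chain carbon. For the measured compounds named here, no measured pair tests a change on the chain, so the step size is uncertain. Compound 4 is expected to give 50 nM, between 8 nM and 300 nM. This estimate corresponds to a step of a 6.3-fold higher number from compound 1 to compound 4 (0.80 log units; beyond the scatter).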

Compound 4, half-maximal effective concentration: 13 nM
Compound 4: middle estimate off by 3.8-fold (0.59 log units), on the high side, and the stated range covers the measured number.
By their numbers in this assay, from the lowest: compound 3; then compounds 2, 1 and 4 (each within the scatter of the next, the first and the last beyond it).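

Swapping 1-hydroxy-2-phenoxyethyl for 3-phenoxypropyl on the double-bonded chain gives a 1.6-fold higher number from compound 1 to compound 4 (0.22 log units; within the scatter) in this assay. The chain's hydroxyl, with its hydrogen-bond donor and defined stereocentre, can therefore be lost without a change beyond the scatter in this read-out. Nothing available explains this result.

Still open, on these data alone, is whether an amine in place of that hydroxyl would also stay within the scatter of compound 1. As far as these compounds go, it is equally open whether a longer chain ending in phenoxy would do so.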